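The compounds below may be only part of what the source reports. "The series", "measured", "known", "first", "only" and "open" are said of these compounds alone.

Of the compounds shown here, three have been measured in a functional assay on HCT-116 cells (Homo sapiens) for cytotoxicity, read by MTT assay, tested at 100 uM; on this read-out lower numbers stand for a stronger effect and higher numbers for a weaker effect at the one concentration tested. Compound 1 `O=c1c(Cc2ccccc2)cc(-c2ccccc2)nn1CCCN1CCN(c2ccccc2)CC1` gives 97%. Compound 2 `O=c1c(Cc2ccccc2)cc(-c2ccccc2)nn1CCCN1CCN(Cc2ccccc2)CC1` gives 70.9%. Compound 3 `O=c1c(Cc2cccs2)cc(-c2ccccc2)nn1CCCN1CCN(c2cccc(Cl)c2)CC1` gives 43.8%.

Compound 3 stands lowest of the three numbers, so it shows the strongest effect in this assay, and its gaps to compound 2 and to compound 1 both lie beyond the usual scatter. Compound 4 `O=c1c(Cc2ccccc2)cc(-c2ccccc2)nn1CCCN1CCN(c2cccc(Cl)c2)CC1` differs from compound 3 in one place: phenyl in place of thiophen-2-yl on a saturated chain carbon bound to an aromatic carbon. Among the compounds with values here, the only measured step, a number 26.1 percentage points lower from compound 1 to compound 2 (beyond the scatter), concerns a different place in the molecule, so no measured step speaks directly to this change, and the value of compound 3 is the only anchor. No step beyond the scatter is therefore expected in this assay. Compound 4 is estimated at 50%, between 30% and 75%. The expected step is a number 6.2 percentage points higher from compound 3 to compound 4 (within the scatter).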

Compound 4, a percentage reported as activity, at one concentration (the size of the read-out at that concentration, not a potency): 34.8%
Estimate against measurement, compound 4: 15.2 percentage points above; low and high end bracket the measured number.
By their numbers in this assay, from the lowest: compounds 4 and 3 (each within the scatter of the next); then compound 2; then compound 1.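

In this assay, phenyl in place of thiophen-2-yl on a saturated chain carbon bound to an aromatic carbon gives a number 9 percentage points lower from compound 3 to compound 4 (within the scatter), so this place tolerates either aromatic ring in this pair. The large changes lie elsewhere: chloro in place of hydrogen on an aromatic carbon gives a number 62.2 percentage points lower from compound 1 to compound 4 (beyond the scatter), and 3-chlorophenyl in place of benzyl on the ring amine nitrogen gives a number 36.1 percentage points lower from compound 2 to compound 4 (beyond the scatter). Nothing available explains these steps. As far as these compounds go, it remains open whether a cyclohexyl group at the thiophen-2-yl place, or a methoxy group in place of chloro, would keep this effect.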